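Fluoropyridyl for pyrimidinyl on the ring amide nitrogen

The compounds below may be only part of what the source reports. "The series", "measured", "known", "first", "only" and "open" are said of these compounds alone.

Measured so far:
compound 1 `O=C1O[C@]2(CC[C@H](CNc3cnn(-c4ccccc4F)c3)CC2)CN1c1cncnc1` — 0.0398 nM
compound 2 `O=C1O[C@]2(CC[C@H](CNc3ccc(-c4nccs4)cn3)CC2)CN1c1ccccn1` — 0.126 nM

In a functional assay for antagonist activity at Neuropeptide Y receptor type 5 (Homo sapiens) (a higher number here means a weaker inhibitor, a lower number a stronger inhibitor), compound 1 gives the lower of the two numbers; compound 2 gives a number beyond the scatter above it. Compound 3 `O=C1O[C@]2(CC[C@H](CNc3cnn(-c4ccccc4F)c3)CC2)CN1c1cccnc1F` is not yet measured and differs from compound 1 by 2-fluoropyridin-3-yl in place of pyrimidin-5-yl on an amide-type nitrogen in a ring. Within the data shown here, no measured pair shows this change, so its size is unknown; only a modest shift, if any, is expected. The step from compound 1 to compound 3 is estimated as a 1.8-fold higher number from compound 1 to compound 3 (0.25 log units; within the scatter). For compound 3 the expected value in this assay is 0.07 nM, in the range 0.02 nM to 0.3 nM.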

Compound 3, inhibition constant: 0.1 nM
Compound 3: middle estimate off by 1.4-fold (0.15 log units), on the low side; the range from low to high includes it.
By their numbers in this assay, from the lowest: compound 1; then compounds 3 and 2 (each within the scatter of the next).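

Among these compounds, on the amide-type nitrogen of the shared core, 2-fluoropyridin-3-yl in place of pyrimidin-5-yl gives a 2.5-fold higher number from compound 1 to compound 3 (0.40 log units; beyond the scatter) in this assay, a modest loss and the first reading of this change. The position therefore tolerates this swap, and compound 3 still gives 0.1 nM in this assay. No measured data account for the step. Still open, as far as these compounds go, is whether the step belongs to the fluorine or to the change of ring, and a plain pyridin-3-yl on the same nitrogen would separate the two.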